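Isopropoxy on compound 3: what to expect

A few compounds are considered here, and "the series" means these few. Any claim that something is new, unique, unknown or untested is made for them only; others in the source may bear on it.

In a functional assay on A549 cells (Homo sapiens) for antiproliferative activity, read by MTT assay, with a stated time of 72 h (on this read-out lower numbers stand for stronger inhibition and higher numbers for weaker inhibition), compound 1 (`COc1cc(-n2ncnc2-c2ccc(C)cc2)cc(OC)c1OC`) gives 1100 nM. Compound 2 (`COc1cc(-n2ncnc2-c2ccc(Cl)cc2)cc(OC)c1OC`) reads > 10000 nM, which is a limit and not a number. Compound 3 (`COc1cc(-n2ncnc2-c2ccccc2)cc(OC)c1OC`) reads > 10000 nM, also a limit. Compound 3 thus stands at the limit of > 10000 nM in this assay, at which 2 of the 3 values shown sit.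

Compound 4 (`COc1cc(-n2ncnc2-c2ccc(OC(C)C)cc2)cc(OC)c1OC`) is compound 3 with isopropoxy in place of hydrogen on an aromatic carbon. The guides are changes at that same place, an at least 9.0-fold higher number from compound 1 to compound 3 (0.95 log units; beyond the scatter) and an at least 9.0-fold higher number from compound 1 to compound 2 (0.95 log units; beyond the scatter). So the group there can matter, yet chloro gave no readable number, and isopropoxy itself is untested. A step to a lower number is expected, of similar size, though compound 4 may stay at the limit. The expected step is an at least 3.3-fold lower number from compound 3 to compound 4 (0.52 log units; beyond the scatter). For compound 4 the estimated value is 3000 nM, with an expected range from 500 nM to 10000 nM.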

Compound 4, half-maximal inhibitory concentration: > 10000 nM
Compound 4 was reported as a limit; the forecaster's own chance of this, stated with the estimate: 35%; middle value at least 3.3-fold (0.52 log units) away from the limit.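

Going by these compounds alone, compound 4 gives a limit and not a number, so methyl in compound 1 remains the only group at this place with a measured value: the limit of > 10000 nM in this assay, at which 3 of the 4 values shown sit. Isopropoxy in place of methyl gives an at least 9.0-fold higher number from compound 1 to compound 4 (0.95 log units; beyond the scatter), which shows that a larger group here, even one with an oxygen, does not keep the activity of compound 1. The steps from compound 2 and compound 3 to compound 4 cannot be read, as both ends are limits.

Going by these compounds, whether ethyl or an amine at this place would give a readable number stays open.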